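Hydrogen in place of methyl: compound 3 to compound 4

A few compounds are considered here, and "the series" means these few. Any claim that something is new, unique, unknown or untested is made for them only; others in the source may bear on it.

Measured in an ADME assay on microsomes from liver (Rattus norvegicus) for pharmacokinetics; a higher number here means faster removal of the compound, a lower number slower removal:
- compound 1 `Cn1cc(-c2ncc(C#N)c(N3C[C@@H]4C[C@H]3CN4CC3CC3)n2)cn1`: 158 mL/min/kg
- compound 2 `Cn1cc(-c2ncc(C#N)c(N3C[C@@H]4C[C@H]3CN4S(=O)(=O)C3CC3)n2)cn1`: < 36 mL/min/kg (a limit)
- compound 3 `C[C@@H]1CN(c2nc(-c3cnn(C)c3)ncc2C#N)CCN1C(=O)C1(C)CC1`: < 36 mL/min/kg (a limit)

Compound 3 gives < 36 mL/min/kg, which is a limit and not a number. Compound 3 thus sits at the limit of < 36 mL/min/kg in this assay, at which 2 of the 3 values shown sit. Compound 4 `C[C@@H]1CN(c2nc(-c3cnn(C)c3)ncc2C#N)CCN1C(=O)C1CC1` carries hydrogen in place of methyl on a saturated ring carbon, with cyclopropyl in place of 1-methylcyclopropyl. Among the measured compounds shown here, the only measured step, an at least 4.3-fold lower number from compound 1 to compound 2 (0.64 log units; beyond the scatter), is a different change, cyclopropylsulfonyl in place of cyclopropylmethyl, and sets no size for this one. The estimated step in this assay is a step that the limit leaves unreadable from compound 3 to compound 4, and none beyond the scatter is expected. The estimate for compound 4 is 32 mL/min/kg, expected within 18 mL/min/kg to 60 mL/min/kg.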

Compound 4, clearance: < 36 mL/min/kg
Compound 4: a limit, no number; the forecaster's own chance of this, stated with the estimate: 65%; the middle value lies beyond the limit too.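

Compound 3 and compound 4 both give a limit and not a number, so no step can be read between them: the limit of < 36 mL/min/kg in this assay, at which 3 of the 4 values shown sit.

As far as these compounds go, the size of any effect of hydrogen in place of methyl on a saturated ring carbon in this assay remains open.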